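A few compounds are considered here, and "the series" means these few. Any claim that something is new, unique, unknown or untested is made for them only; others in the source may bear on it.

Measured in a functional assay on MOLT-4 cells (Homo sapiens) for inhibition; on this read-out higher numbers stand for weaker inhibition and lower numbers for stronger inhibition:
compound 1 `O=C1/C(=C/c2cccc(Cl)c2)Cc2ccccc21` gives 50900 nM
compound 2 `O=C1/C(=C/c2cccc(F)c2)CCc2ccccc21` gives 11900 nM
compound 3 `O=C1/C(=C/c2cccc(Br)c2)CCCc2ccccc21` gives 17100 nM

Compound 3 at 17100 nM and compound 2 at 11900 nM lie within the usual scatter of each other. Compound 1 at 50900 nM reads clearly higher than compound 3, which means weaker inhibition.

Compound 4 `O=C1/C(=C/c2cccc([N+](=O)[O-])c2)CCCc2ccccc21` has nitro in place of bromo on an aromatic carbon, meta to a large group (nitro in place of bromo on an aromatic carbon). Among the measured compounds shown here, no measured pair shows this swap alone, so its size is unknown. With compound 3 at 17100 nM as the only anchor, no change beyond the scatter is expected in this assay for this swap. The estimated step of a 1.1-fold lower number from compound 3 to compound 4 (0.06 log units; within the scatter) is therefore small. Compound 4 is expected at 15000 nM with a likely range from 6000 nM to 40000 nM in this estimate.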

Compound 4, half-maximal inhibitory concentration: 8820 nM
For compound 4 the middle estimate is 1.7-fold (0.23 log units) above the measured one; measured number inside the range.
By their numbers in this assay, from the lowest: compounds 4, 2 and 3 (each within the scatter of the next); then compound 1.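

Putting nitro in place of bromo on this aromatic carbon gives a 1.9-fold lower number from compound 3 to compound 4 (0.29 log units; within the scatter) in this assay, so the two compounds cannot be told apart on this read-out. At this position, then, 3 heavy atoms and 2 hydrogen-bond acceptors can stand where bromo has 1 heavy atom and none, with no step beyond the scatter. Nothing measured here bears on why the two read alike. On these data alone, how an amine or a carboxylic acid would read on this same carbon stays open. As far as these compounds go, compound 1 and compound 2 each differ from compound 4 in more than one place, so whether this swap reads the same on their cores also stays open.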